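Methyl for methoxy on the anilide of compound 3

A few compounds are considered here, and "the series" means these few. Any claim that something is new, unique, unknown or untested is made for them only; others in the source may bear on it.

Measured so far:
compound 1 `COc1ccc2c(=O)c(/C=C/C(=O)Nc3ccccc3)coc2c1` gives 9050 nM
compound 2 `CCOc1ccc(NC(=O)/C=C/c2coc3cc(OC)ccc3c2=O)cc1` gives 3230 nM
compound 3 `COc1cccc(NC(=O)/C=C/c2coc3cc(OC)ccc3c2=O)c1` gives 11100 nM

In a functional assay on Huh-7 cells (Homo sapiens) for inhibition, read by MTT assay, with a stated time of 48 h (on this read-out lower numbers stand for stronger inhibition and higher numbers for weaker inhibition), compound 3 has the highest of the three numbers. Its nearest neighbour is compound 1, with the two values sitting within the scatter of each other; the step of a 3.4-fold higher number from compound 2 to compound 3 (0.54 log units; beyond the scatter) is the only one that sets it clearly apart. Compound 4 `COc1ccc2c(=O)c(/C=C/C(=O)Nc3cccc(C)c3)coc2c1` is not yet measured. It differs from compound 3 in one place: methyl in place of methoxy on an aromatic carbon.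

Among the measured compounds shown here, no measured step swaps methyl for methoxy directly. The closest guide is a 1.2-fold higher number from compound 1 to compound 3 (0.09 log units; within the scatter), which shows that a methoxy on the ring of compound 1, at this same position, changed the number by an amount inside the scatter. For the measured compounds named here, the one step that moved the number beyond the scatter, a 2.8-fold lower number from compound 1 to compound 2 (0.45 log units; beyond the scatter), concerns a different group at a different place on the same ring, and so bears only loosely on the change at hand. From this the step to compound 4 is expected to be small, most likely within the scatter, with a slight lean towards a lower number: a 1.2-fold lower number from compound 3 to compound 4 (0.09 log units; within the scatter). Compound 4 is thus estimated at 9000 nM, with a plausible range from 4000 nM to 22000 nM.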

Compound 4, half-maximal inhibitory concentration: 15500 nM
The estimate for compound 4 lay 1.7-fold (0.24 log units) below the measured number, and the stated range covers the measured number.
By their numbers in this assay, from the lowest: compound 2; then compounds 1, 3 and 4 (each within the scatter of the next).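

In this assay the change from methoxy to methyl gives a 1.4-fold higher number from compound 3 to compound 4 (0.15 log units; within the scatter) and so shows that, on this carbon meta to a large group, losing the hydrogen-bond acceptor of the methoxy and one heavy atom does not separate the two values. Methyl in place of hydrogen at this position gives a 1.7-fold higher number from compound 1 to compound 4 (0.23 log units; within the scatter) and stays inside the scatter as well, so hydrogen, methoxy and methyl here cannot be told apart, whereas 3-methylphenyl in place of 4-ethoxyphenyl gives a 4.8-fold higher number from compound 2 to compound 4 (0.68 log units; beyond the scatter) and leaves compound 2 clearly apart from compound 4. Nothing measured alongside these numbers speaks to why the values fall as they do.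

The compounds shown leave open whether this position stays as unresponsive with an amine or a carboxylic acid on the same carbon, since hydrogen, methyl and methoxy span only a narrow set of groups. They also leave open whether the lower number of compound 2 goes with the ethoxy group itself or with where it sits, as the steps in hand change group and place together.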